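Working notes on a one-carbon chain extension in two cores

The source may hold more compounds than are shown below. What is called first, only, known or untested is meant among the compounds shown, and "the series" means these compounds.

Measured compounds:
compound 1 `CCc1ccccc1OS(=O)(=O)c1ccc(NC(=O)NCCCCl)cc1`, giving 15000 nM in a functional assay on HT-29 cells (Homo sapiens) for cytotoxicity, read by sulforhodamine B assay, with a stated time of 48 h; a lower number here means a stronger inhibitor, a higher number a weaker inhibitor
compound 2 `CCCc1ccccc1OS(=O)(=O)c1ccc(NC(=O)NCCCCl)cc1`, giving 13000 nM in this assay
compound 3 `CCNC(=O)Nc1ccc(S(=O)(=O)Nc2ccccc2C)cc1`, for which this assay reports only a limit, > 200000 nM

Compound 1 and compound 2 share one core and differ only by methyl in place of hydrogen on a saturated chain carbon, two bonds along the chain from an aromatic carbon. That change produced a 1.2-fold lower number from compound 1 to compound 2 (0.06 log units; within the scatter). Compound 3 carries a different core; how the two cores differ is not broken down here.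

Compound 4 `CCNC(=O)Nc1ccc(S(=O)(=O)Nc2ccccc2CC)cc1` is not yet measured and differs from compound 3 by methyl in place of hydrogen on a saturated chain carbon bound to an aromatic carbon. This is the same kind of change as from compound 1 to compound 2, but not the same: there the carbon sits two bonds along the chain from an aromatic carbon, here it is bound to an aromatic carbon. Compound 3 itself sits at the limit of > 200000 nM in this assay, at which 1 of the 3 values shown sits, so the starting point is a limit, not a number.

The step that the limit leaves unreadable from compound 3 to compound 4 is expected to be small, because a 1.2-fold lower number from compound 1 to compound 2 (0.06 log units; within the scatter) stayed within the scatter and because the limit of > 200000 nM in this assay, at which 1 of the 3 values shown sits, leaves no room for the number to rise. Compound 4 is therefore estimated at 250000 nM, between 120000 nM and 500000 nM, most likely again reported only as a limit.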

Compound 4, half-maximal inhibitory concentration: 86000 nM
Estimate against measurement, compound 4: 2.9-fold (0.46 log units) above, outside the stated range (below it).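

In this assay the added methyl gives an at least 2.3-fold lower number from compound 3 to compound 4 (0.36 log units; beyond the scatter), against a 1.2-fold lower number from compound 1 to compound 2 (0.06 log units; within the scatter) on the core of compound 1. Compound 3 is reported only as a limit, > 200000 nM, and not as a number. The size of the step on the core of compound 3 therefore remains unknown, the methyl sits at a different place in each pair, and no transfer of the change from one core to the other, or failure of transfer, is shown: the same change on two cores in this assay, a 1.2-fold lower number (0.06 log units; within the scatter) from compound 1 to compound 2 and an at least 2.3-fold lower number (0.36 log units; beyond the scatter) from compound 3 to compound 4; the limit leaves it open whether they differ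

The compounds shown leave open how a longer chain such as butyl, or an amine or a carboxylic acid at the end of the chain, would read on either core in this assay. They also leave open which of the differences between the two cores matters for the size of this step, since each core is represented here by a single pair.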